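Methylsulfanyl for methyl on the benzylic ring

This account rests on a few compounds, and the source may have more. Where it says the series, first, only, none or still open, it means among the compounds named here.

In a functional assay for antagonist activity at P2X purinoceptor 7 (Homo sapiens), read by FLIPR and calcium flux (a higher number here means a weaker inhibitor, a lower number a stronger inhibitor), compound 1 `COc1ccccc1Nc1ncnn1-c1cccc(Cl)c1Cl` gives 102 nM and compound 2 `Cc1ccccc1CNc1ncnn1-c1cccc(Cl)c1Cl` gives 20.9 nM, the lower of the two numbers; the gap between them lies beyond the usual scatter. Compound 3 `CSc1ccccc1CNc1ncnn1-c1cccc(Cl)c1Cl` differs from compound 2 by methylsulfanyl in place of methyl on an aromatic carbon. Among the measured compounds shown here, no measured pair covers this exchange, so the step expected here is a 1.4-fold higher number from compound 2 to compound 3 (0.16 log units; within the scatter), not beyond the scatter in either direction. Compound 3 is accordingly estimated at 30 nM in this assay, with a range from 10 nM to 90 nM.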

Compound 3, half-maximal inhibitory concentration: 49 nM
The estimate for compound 3 lay 1.6-fold (0.21 log units) below the measured number; the range from low to high includes it.
By their numbers in this assay, from the lowest: compound 2; then compound 3; then compound 1.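

In this assay methylsulfanyl in place of methyl on this aromatic carbon, ortho to a large group, gives a 2.3-fold higher number from compound 2 to compound 3 (0.37 log units; beyond the scatter) and so is tolerated without matching methyl. The sulfur and the hydrogen-bond acceptor that enter with methylsulfanyl bring no gain at this position. No measurement here accounts for the difference. Open, on these data alone, is how an amine, a carboxylic acid or a longer chain would fare on this carbon. Also open, as far as these compounds go, is whether methylsulfanyl would give a similar step on other carbons of the ring.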